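The compounds below may be only part of what the source reports. "The series", "measured", "known", "first", "only" and "open" are said of these compounds alone.

- compound 1 `NCCCCN(C[C@H]1Cc2ncccc2CN1)[C@H]1CCCc2cccnc21`: 100%
- compound 2 `NC(=O)NC/C=C/CN(C[C@H]1Cc2ncccc2CN1)[C@H]1CCCc2cccnc21`: 93%

In an ADME assay on microsomes from liver (Homo sapiens) for metabolic stability, using NADPH, with a stated time of 10 min (a higher number here means that more of the compound is left, a lower number that less of the compound is left), compound 2 gives 93%, which lies within the usual scatter of compound 1 at 100%. The two therefore cannot be told apart on this measurement.

Compound 3 `CCN(CC)CCCCN(C[C@H]1Cc2ncccc2CN1)[C@H]1CCCc2cccnc21` is still unmeasured. Its structural change is a group of 8 heavy atoms (7 carbon, 1 nitrogen; no ring) in place of a group of 7 heavy atoms (4 carbon, 2 nitrogen, 1 oxygen; no ring), on a saturated chain carbon bound to an amine nitrogen. The group that enters is 3-(diethylamino)propyl, on a saturated chain carbon bound to an amine nitrogen.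

Going by the values given here, only one measured step bears on this change: a number 7 percentage points lower from compound 1 to compound 2 (within the scatter). That step also exchanged one ring-free group for another at the same place. Among the compounds with values here, no measured compound carries the 3-(diethylamino)propyl group, so the evidence is thin and the range must stay wide.

No change beyond the scatter is expected, and the estimated step is a number 3 percentage points lower from compound 2 to compound 3 (within the scatter). For compound 3 the expected value is 90%, with an estimated range from 72% to 100%.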

Compound 3, percent of the compound remaining: 80%
The estimate for compound 3 lay 10 percentage points above the measured number; low and high end bracket the measured number.
By their numbers in this assay, from the lowest: compound 3; then compounds 2 and 1 (each within the scatter of the next).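

At this place, on a saturated chain carbon bound to an amine nitrogen, the earlier pair showed no readable difference, whereas this assay now gives a number 13 percentage points lower from compound 2 to compound 3 (beyond the scatter) for the exchange of groups. Putting diethylamino in place of amino alone, on a saturated chain carbon four bonds along the chain from an amine nitrogen, gives a number 20 percentage points lower from compound 1 to compound 3 (beyond the scatter), so the number can move with the group at the end of this chain, though both steps are modest. No measurement at hand says why less of compound 3 is left.

Going by these compounds, whether dimethylamino or a single ethyl on that amine would give a number closer to that of compound 1 stays open. So does the outcome for a ring amine such as pyrrolidine, or for a longer chain.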